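Moving the dimethoxy pattern on compound 1

The source may hold more compounds than are shown below. What is called first, only, known or untested is meant among the compounds shown, and "the series" means these compounds.

Compound 1 `COc1ccc(-c2cc(-c3cc(C(C)C)c(O)cc3C)[nH]c(=O)c2C#N)c(OC)c1` in a functional assay for inhibition, tested at 60 ug/mL (on this read-out lower numbers stand for a weaker effect and higher numbers for a stronger effect at the one concentration tested), gives 48.5%, the lowest of the two numbers in hand. Among the measured compounds shown here, compound 2 `COc1cc(OC)c(-c2cc(-c3cc(C(C)C)c(O)cc3C)[nH]c(=O)c2C#N)c(OC)c1` in this assay gives 66%; the step of a number 17.5 percentage points higher from compound 1 to compound 2 (beyond the scatter) is the only measured step, and it adds a methoxy group rather than relocating one. Compound 3 `COc1ccc(-c2cc(-c3cc(C(C)C)c(O)cc3C)[nH]c(=O)c2C#N)cc1OC` differs from compound 1 by 3,4-dimethoxyphenyl in place of 2,4-dimethoxyphenyl on an aromatic carbon. For the measured compounds named here, no measured step bears directly on this rearrangement; the step from compound 1 to compound 2 shows only that changing the methoxy pattern on this ring can shift the read-out beyond the scatter, and it gives no direction for a change in which the same atoms are joined differently. A step of a number 1.5 percentage points higher from compound 1 to compound 3 (within the scatter) is therefore expected, that is, no change beyond the scatter is anticipated with confidence in either direction. Compound 3 is estimated at 50%, with a range from 32% to 68%.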

Compound 3, a percentage reported as inhibition, at one concentration (the size of the read-out at that concentration, not a potency): 52%
Compound 3: the middle estimate sits 2 percentage points below what was measured; measured number inside the range.
By their numbers in this assay, from the lowest: compounds 1 and 3 (each within the scatter of the next); then compound 2.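

In this assay, 3,4-dimethoxyphenyl in place of 2,4-dimethoxyphenyl gives a step of a number 3.5 percentage points higher from compound 1 to compound 3 (within the scatter), so at this place on the core, this rearrangement of the same two methoxy groups does not separate the two compounds at the one concentration tested. The earlier step, a number 17.5 percentage points higher from compound 1 to compound 2 (beyond the scatter), came from adding a methoxy group, and the new pair shows that a change on this ring need not move the read-out beyond the scatter. Nothing in hand explains either outcome.

As far as these compounds go, whether this ring accepts groups other than methoxy remains open, for example a hydroxy group, a fluorine or a dimethylamino group, as does the read-out of an unsubstituted phenyl ring. From the compounds shown here alone, with a single concentration and no potency, any difference between compound 1 and compound 3 at other concentrations also remains unknown.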